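Lipophilicity notes: 4-cyanophenyl in place of 2-nitrophenyl

The compounds below may be only part of what the source reports. "The series", "measured", "known", "first", "only" and "open" are said of these compounds alone.

Measured compounds in a physicochemical assay for lipophilicity; a lower number here means a more polar compound, a higher number a more lipophilic compound:
- compound 1 `C[C@H]1CC[C@@H]2[C@@H](OC(=O)[C@]23CC(c2ccccc2)=NO3)[C@]2(C)C(=O)C=C[C@@]12O` gives 1.41
- compound 2 `C[C@H]1CC[C@@H]2[C@@H](OC(=O)[C@]23CC(c2ccccc2[N+](=O)[O-])=NO3)[C@]2(C)C(=O)C=C[C@@]12O` gives 1.37
- compound 3 `COc1cc(C2=NO[C@]3(C2)C(=O)O[C@@H]2[C@H]3CC[C@H](C)[C@]3(O)C=CC(=O)[C@@]23C)ccc1O` gives 0.75

Compound 2 stands second highest of the three numbers. Its nearest neighbour is compound 1, the gap being a number 0.04 log units lower from compound 1 to compound 2 (within the scatter), which is within the scatter. Its furthest is compound 3, separated by a number 0.62 log units lower from compound 2 to compound 3 (beyond the scatter), a modest step beyond the scatter; compound 1 shows the same direction with a number 0.66 log units lower from compound 1 to compound 3 (beyond the scatter).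

Compound 4 `C[C@H]1CC[C@@H]2[C@@H](OC(=O)[C@]23CC(c2ccc(C#N)cc2)=NO3)[C@]2(C)C(=O)C=C[C@@]12O` has not yet been measured. It differs from compound 2 as follows: 4-cyanophenyl in place of 2-nitrophenyl on a carbon with a double bond to nitrogen.

The step that bears on this change is a number 0.04 log units lower from compound 1 to compound 2 (within the scatter), since it shows the nitro group on the aromatic carbon by itself changing the number only within the scatter. Among the compounds with values here, no measured step shows a 4-cyanophenyl at this position, so the cyano contribution is not anchored. The expectation for compound 4 is therefore a small step, not clearly beyond the scatter, of a number 0.12 log units lower from compound 2 to compound 4 (within the scatter). For compound 4 the estimate in this assay is 1.25, with a range from 0.9 to 1.6.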

Compound 4, partition coefficient: 1.17
Beside the measured number, compound 4's estimate is 0.08 log units above it; low and high end bracket the measured number.
By their numbers in this assay, from the lowest: compound 3; then compounds 4, 2 and 1 (each within the scatter of the next).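

In this assay, the nitrile-bearing ring adds a second substituent type at this position without a resolved shift: 4-cyanophenyl in place of 2-nitrophenyl gives a number 0.20 log units lower from compound 2 to compound 4 (within the scatter), and cyano in place of hydrogen on the aromatic carbon gives a number 0.24 log units lower from compound 1 to compound 4 (within the scatter). Within the data shown here, compound 3 remains the one compound set apart, now also against a nitrile-bearing partner, with a number 0.42 log units higher from compound 3 to compound 4 (beyond the scatter), so 4-hydroxy-3-methoxyphenyl is the only group here whose separation from each of the other three lies beyond the scatter. No supporting measurement bears on why the steps fall this way.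

Still open, from the compounds shown here alone, is whether a phenyl carrying only a hydroxy or only a methoxy accounts for the separation of compound 3. Going by these compounds, it is also open whether an amine or a carboxylic acid on the phenyl ring would move the number beyond the scatter.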